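The source may hold more compounds than are shown below. What is called first, only, known or untested is meant among the compounds shown, and "the series" means these compounds.

Working notes on the series in a functional assay on A549 cells (Homo sapiens) for antiproliferative activity, read by MTT assay, with a stated time of 72 h; on this read-out lower numbers stand for stronger inhibition and higher numbers for weaker inhibition. Compound 1 (`COc1cc(-c2ncnn2-c2cccc(N)c2)cc(OC)c1OC`) gives only a limit, > 10000 nM. Compound 2 (`COc1cccc(-c2ncnn2-c2cc(OC)c(OC)c(OC)c2)c1`) also gives only a limit, > 10000 nM. Compound 3 (`CCOc1cccc(-c2ncnn2-c2cc(OC)c(OC)c(OC)c2)c1`) likewise gives only a limit, > 10000 nM, so its standing against the other two cannot be read. The whole set so far reads as the limit of > 10000 nM in this assay, at which 3 of the 3 values shown sit.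

The next structure is compound 4 (`COc1cc(-n2ncnc2-c2cccc([N+](=O)[O-])c2)cc(OC)c1OC`), with nitro in place of ethoxy on an aromatic carbon, meta to a large group: nitro in place of ethoxy on an aromatic carbon. Among the measured compounds shown here, the only measured step, a step that the two limits leave unreadable from compound 2 to compound 3, has no readable size and sets no scale for this change. No numerical value exists yet in the set, so no step beyond the scatter is expected and no direction can be argued. The expectation rests on compound 3 and its limit of > 10000 nM. The estimated change, a step that the limit leaves unreadable from compound 3 to compound 4, is expected to be small. Compound 4 is expected to give about 15000 nM, with an estimated range from 3000 nM to 50000 nM, most likely reported only as a limit.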

Compound 4, half-maximal inhibitory concentration: > 10000 nM
Compound 4 was reported as a limit (the forecaster's own chance of this, stated with the estimate: 80%); the middle value lies beyond the limit too.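

Compound 4 gives only a limit in this assay, > 10000 nM. No new step can be read: those from compound 2 and compound 3 to compound 4 stay unreadable. The compounds shown leave open whether methoxy, ethoxy and nitro differ at all in this assay.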